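Adding a (dimethylamino)methyl group to the hydroxy-bearing ring

The compounds below may be only part of what the source reports. "The series", "measured", "known", "first", "only" and "open" are said of these compounds alone.

This account concerns two measured compounds and one whose result is still to come. Compound 1 `C=CC[C@@]12CCN(C(=O)OC(C)(C)C)[C@@H]1n1c3nc4ccc(O)cc4cc3c(=O)c3cccc2c31` was tested in a functional assay on HeLa cells (Homo sapiens) for inhibition, read by trypan blue exclusion, with a stated time of 72 h (a lower number here means a stronger inhibitor of growth, a higher number a weaker inhibitor of growth), where compound 1 gives 30500 nM. Compound 2 `CC(C)(C)OC(=O)N1CC[C@@]2(CCO)c3cccc4c(=O)c5cc6cc(O)ccc6nc5n(c34)[C@@H]12` differs from it only on the saturated chain, and in this assay compound 2 gives 13000 nM. Among the compounds with values here, that change, a 2.3-fold lower number from compound 1 to compound 2 (0.37 log units; beyond the scatter), is the only step recorded, and among the two numbers compound 1 holds the highest, with compound 2 as its nearest neighbour.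

Compound 3 `C=CC[C@@]12CCN(C(=O)OC(C)(C)C)[C@@H]1n1c3nc4ccc(O)c(CN(C)C)c4cc3c(=O)c3cccc2c31` keeps the chain of compound 1 unchanged and instead alters the aromatic ring: (dimethylamino)methyl in place of hydrogen on an aromatic carbon. Within the data shown here, no measured step touches this position, so the step from compound 1 to compound 2 does not bear directly on the new change, and no guidance on direction or size can be drawn from it. The expectation for compound 3 therefore rests on compound 1 alone, with a wide range, and a step of a 1.7-fold lower number from compound 1 to compound 3 (0.23 log units; within the scatter) is estimated, which may not exceed the scatter. In this assay compound 3 is expected to give 18000 nM, within 5000 nM to 60000 nM.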

Compound 3, concentration for 50% growth inhibition: 35200 nM
For compound 3 the middle estimate is 2.0-fold (0.29 log units) below the measured one; the measured number falls inside the stated range.
By their numbers in this assay, from the lowest: compound 2; then compounds 1 and 3 (each within the scatter of the next).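

In this assay, (dimethylamino)methyl in place of hydrogen on this aromatic carbon, ortho to a hydroxy group, gives a 1.2-fold higher number from compound 1 to compound 3 (0.06 log units; within the scatter), so compound 1 and compound 3 cannot be told apart by this read-out. Within the data shown here, this is the first reading at this position, since the earlier step concerned only the saturated chain, and it shows that this group can stand here without a step beyond the scatter. No measurement is at hand that could explain this result.

The compounds shown leave open whether another aminomethyl group on the same carbon, such as (pyrrolidin-1-yl)methyl or morpholinomethyl, or a plain methyl group would give a reading that stands apart from that of compound 1. They also leave open whether (dimethylamino)methyl at this position would leave the number unchanged on the core of compound 2, which differs from compound 1 on the saturated chain and gives the lowest number of the three.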